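Cyano in place of methoxy on compound 1

A few compounds are considered here, and "the series" means these few. Any claim that something is new, unique, unknown or untested is made for them only; others in the source may bear on it.

In a functional assay on KBVIN cells (Homo sapiens) for antiproliferative activity, read by sulforhodamine B assay, with a stated time of 48 h (a lower number here means a stronger inhibitor of growth, a higher number a weaker inhibitor of growth), compound 1 (`COc1ccc(Nc2nc(NC3CCCC3)c3ccccc3n2)cc1`) gives 12600 nM and compound 2 (`CNc1nc(Nc2ccc(OC)cc2)nc2ccccc12`) gives 17500 nM so the two numbers stand within the scatter of each other and neither can be ranked ahead. Compound 3 (`N#Cc1ccc(Nc2nc(NC3CCCC3)c3ccccc3n2)cc1`) keeps the core and the cyclopentyl group of compound 1 and changes one group (cyano in place of methoxy on an aromatic carbon) so that 4-methoxyphenyl becomes 4-cyanophenyl. Among the compounds with values here, the only measured step is a 1.4-fold higher number from compound 1 to compound 2 (0.14 log units; within the scatter) and it concerns methyl in place of cyclopentyl, a different place from the one changing here. Within the data shown here, no measured pair shows what cyano in place of methoxy does, so that single step offers only a rough guide to size, and a small one. No step beyond the scatter is therefore expected in this assay and neither direction is favoured, though the uncertainty is wide. The estimate amounts to an expected 1.1-fold higher number from compound 1 to compound 3 (0.05 log units; within the scatter) as the step. Compound 3 is expected to give about 14000 nM with an estimated range from 5000 nM to 40000 nM until it is measured.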

Compound 3, concentration for 50% growth inhibition: > 31300 nM
Compound 3 was reported as a limit; the forecaster's own chance of this, stated with the estimate: 15%; middle value at least 2.2-fold (0.34 log units) away from the limit.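

In this assay compound 3 is reported only as a limit, > 31300 nM, and not as an exact number. Replacing 4-methoxyphenyl with 4-cyanophenyl gives an at least 2.4-fold higher number from compound 1 to compound 3 (0.39 log units; beyond the scatter), so a change on this aromatic carbon, para to a large group, moves the read-out beyond the scatter, which the swap of cyclopentyl for methyl in compound 2 did not do. Within the data shown here, this is the first step that can be given a direction, toward weaker inhibition of growth, but its full size stays unknown, and the figure is only a lower bound on the step: the limit of > 31300 nM in this assay, at which 1 of the 3 values shown sits.

With a single replacement at this place, the compounds shown cannot tell whether the methoxy group helps growth inhibition or the cyano group harms it, and what an amine or a longer chain such as ethoxy would give on this carbon remains open. Also open, as far as these compounds go, is whether cyano in place of methoxy would produce a similar step in compound 2, where methyl stands in place of cyclopentyl.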